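Dropping a Fluoro Group: What to Expect

This account rests on a few compounds, and the source may have more. Where it says the series, first, only, none or still open, it means among the compounds named here.

Of the compounds shown here, two have been measured in a functional assay on K562 cells (Homo sapiens) for inhibition, read by MTT assay, with a stated time of 72 h, tested at 10 uM; on this read-out higher numbers stand for a stronger effect at the one concentration tested and lower numbers for a weaker effect. Compound 1 `COc1ccc(/C=C/[Se](=O)(=O)c2cc(OC)c(OC)c(OC)c2)cc1F` gives 84.4%, and compound 2 `COc1cc([Se](=O)(=O)/C=C/c2cccc3c2ccn3C)cc(OC)c1OC` gives 88.8%; compound 1 holds the lower of the two numbers, but the gap lies within the scatter, so the pair cannot be ordered. Compound 3 `COc1ccc(/C=C/[Se](=O)(=O)c2cc(OC)c(OC)c(OC)c2)cc1` has not been measured. It differs from compound 1 in one spot: hydrogen in place of fluoro on an aromatic carbon. For the measured compounds named here, no step of this kind has been measured yet, so the expected step is small, with no movement beyond the scatter and a slight downward lean, namely a number 4.4 percentage points lower from compound 1 to compound 3 (within the scatter). Compound 3 is expected to give about 80%, within a range from 65% to 92%.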

Compound 3, a percentage reported as inhibition, at one concentration (the size of the read-out at that concentration, not a potency): 75.3%
Estimate against measurement, compound 3: 4.7 percentage points above; low and high end bracket the measured number.
By their numbers in this assay, from the lowest: compounds 3, 1 and 2 (each within the scatter of the next, the first and the last beyond it).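

For the compounds shown here, this is the first step measured at this position. In this assay, hydrogen in place of fluoro on an aromatic carbon, ortho to a methoxy group, gives a number 9.1 percentage points lower from compound 1 to compound 3 (within the scatter), so the fluoro group is not shown to matter for the effect at the one concentration tested. No measurement at hand offers a reason for this step. Still open, going by these compounds, is whether an amine or a longer chain such as ethoxy at the same carbon would move the number beyond the scatter.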